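From Nitrophenyl to Hydroxymethoxyphenyl: An Expected Shift

The source may hold more compounds than are shown below. What is called first, only, known or untested is meant among the compounds shown, and "the series" means these compounds.

Compound 1 `O=c1oc2ccc(Cl)cc2c(O)c1C(c1cccc([N+](=O)[O-])c1)c1c(O)c2cc(Cl)ccc2oc1=O` carries a 3-nitrophenyl group on a saturated chain carbon bound to two aromatic carbons. In an assay on isolated protein for inhibition of Maltase-glucoamylase (Homo sapiens) (on this read-out lower numbers stand for stronger inhibition and higher numbers for weaker inhibition), compound 1 gives 27100 nM. Among the measured compounds shown here, this is the lowest of the two numbers measured so far. For the measured compounds named here, the only other measured compound, compound 2 `CCOc1cc(C(c2c(O)c3cc(C)ccc3oc2=O)c2c(O)c3cc(C)ccc3oc2=O)ccc1O`, differs from compound 1 in several places at once; in this assay compound 2 gives 221000 nM, a number far beyond the usual scatter away from that of compound 1.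

Compound 3 `COc1cc(C(c2c(O)c3cc(Cl)ccc3oc2=O)c2c(O)c3cc(Cl)ccc3oc2=O)ccc1O` is the compound still to be measured. Its change from compound 1 is 4-hydroxy-3-methoxyphenyl in place of 3-nitrophenyl on a saturated chain carbon bound to two aromatic carbons. Going by the values given here, no step between measured compounds isolates this change, so the expectation rests on what the two numbers show: compound 2, which also carries a hydroxy-alkoxyphenyl group, gives 221000 nM, a much weaker result than compound 1.

The step from compound 1 to compound 3 is therefore expected to be a weakening one, a 3.0-fold higher number from compound 1 to compound 3 (0.47 log units; beyond the scatter), beyond the scatter. Compound 3 is estimated at 80000 nM, with a likely range from 25000 nM to 250000 nM.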

Compound 3, half-maximal inhibitory concentration: 83600 nM
Compound 3: the middle estimate sits 1.0-fold (0.02 log units) below what was measured; the measured number falls inside the stated range.
By their numbers in this assay, from the lowest: compound 1; then compound 3; then compound 2.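

In this assay, among the compounds shown here, putting 4-hydroxy-3-methoxyphenyl in place of 3-nitrophenyl on a saturated chain carbon bound to two aromatic carbons gives a 3.1-fold higher number from compound 1 to compound 3 (0.49 log units; beyond the scatter), and this is the first change in one place whose size can be read directly. It shows that this position is not indifferent to what it carries: both groups have 9 heavy atoms and one six-membered aromatic ring of carbon only, yet the step lies beyond the scatter, with the 3-nitrophenyl group giving the lower number and so the stronger inhibition. Nothing measured here bears on what lies behind this step, which rests on a single pair of compounds.

The compounds shown change several features of the group together, so it remains open whether the nitro, hydroxy or methoxy group accounts for the step, and a phenyl group carrying only one of them would help separate these. Also open, on these data alone, is how an amine or a carboxylic acid on the phenyl ring would read in this assay.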